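Two measured amides and one unmeasured analogue

The compounds below may be only part of what the source reports. "The series", "measured", "known", "first", "only" and "open" are said of these compounds alone.

Measured so far:
compound 1, `CCCCN1CCC(C(=O)Nc2ccc(CNc3nc(N(C)C)nc4cc(C)ccc34)cc2)CC1`: > 10500 nM
compound 2, `Cc1ccc2c(NCc3ccc(NC(=O)C4CCN(Cc5ccccc5)CC4)cc3)nc(N3CCN[C@@H](C)C3)nc2c1`: > 8860 nM

In a functional assay on SV5A8 cells (Homo sapiens) for cytotoxicity (on this read-out lower numbers stand for stronger inhibition and higher numbers for weaker inhibition), compound 1 gives > 10500 nM, which is a limit of the assay and not a number. In the same read-out compound 2 gives > 8860 nM, again a limit rather than a measured number. Of the two values shown, one sits at the limit of > 10500 nM in this assay, at which 1 of the 2 values shown sits, and the other at the limit of > 8860 nM in this assay, at which 1 of the 2 values shown sits. Both are limits, so compound 2 stands nowhere on a numerical scale, and no ordering of compound 1 against compound 2 can be read from them. Going by the values given here, no step between measured compounds is recorded.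

Compound 3 is `Cc1ccc2c(NCc3ccc(NC(=O)C4CCN(Cc5ccccc5)CC4)cc3)nc(N3CCCCCC3)nc2c1`. It differs from compound 2 in one place: azepan-1-yl in place of 3-methylpiperazin-1-yl on an aromatic carbon. No measured step touches this position among the compounds shown, so the size of the change cannot be taken from data. Compound 2 sits at a limit in this assay. Compound 3 is therefore expected to stay at a comparable level, with a step that the limit leaves unreadable from compound 2 to compound 3 that is not expected to go beyond the scatter. The estimate for compound 3 is 15000 nM, with a range from 5000 nM to 50000 nM, and a further limit rather than a number is the likelier outcome.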

Compound 3, half-maximal inhibitory concentration: > 6880 nM
Compound 3 ended at the assay's limit (the forecaster's own chance of this, stated with the estimate: 80%); the middle value lies beyond the limit too.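

In this assay compound 3 gives > 6880 nM, a limit of the assay and not a number. Going by these compounds alone, compound 2 also sits at a limit, so no step between compound 2 and compound 3 can be read. The compounds shown leave open where any of them lies on a numerical scale, and whether azepan-1-yl in place of 3-methylpiperazin-1-yl changes the read-out at all.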